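Swapping pyridin-2-yl for 5-bromofuran-2-yl on compound 2

The source may hold more compounds than are shown below. What is called first, only, known or untested is meant among the compounds shown, and "the series" means these compounds.

In a functional assay on NCI-H460 cells (Homo sapiens) for cytotoxicity, read by MTT assay, with a stated time of 72 h (a higher number here means a weaker inhibitor, a lower number a stronger inhibitor), compound 1 (`O=C(c1ccc(F)cc1)c1cccc(/C=c2\[nH]c(=O)/c(=C/c3nc[nH]c3C3CC3)[nH]c2=O)c1`) gives 2.8 nM while compound 2 (`O=c1[nH]/c(=C\c2ccccn2)c(=O)[nH]/c1=C\c1cccc(Oc2ccc(F)cc2)c1`) gives 49.1 nM and so holds the higher of the two numbers, a gap well beyond the usual scatter of repeat measurements. Compound 3 (`O=c1[nH]/c(=C\c2ccc(Br)o2)c(=O)[nH]/c1=C\c1cccc(Oc2ccc(F)cc2)c1`) has not been measured yet. The change from compound 2 to compound 3 is 5-bromofuran-2-yl in place of pyridin-2-yl on a double-bonded chain carbon bound to an aromatic carbon and it sits on a double-bonded chain carbon bound to an aromatic carbon. For the measured compounds named here, the two measured compounds differ in more than one place, so no measured step speaks directly to this swap. In this assay no move beyond the scatter is expected in either direction. The expected change is a 1.2-fold lower number from compound 2 to compound 3 (0.09 log units; within the scatter) and this estimate is a loose one. For compound 3 the estimated value is 40 nM with an expected range from 10 nM to 160 nM as the likely span.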

Compound 3, half-maximal inhibitory concentration: 361 nM
Beside the measured number, compound 3's estimate is 9.0-fold (0.96 log units) below it; measured number above the stated range.
By their numbers in this assay, from the lowest: compound 1; then compound 2; then compound 3.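

In this assay the swap of pyridin-2-yl for 5-bromofuran-2-yl gives a 7.4-fold higher number from compound 2 to compound 3 (0.87 log units; beyond the scatter) and so provides the first direct sign that the group on this double-bonded chain carbon bound to an aromatic carbon matters for the number read out. The change in the number is not matched by the simple counts, since both groups have the same number of heavy atoms, hydrogen-bond donors and hydrogen-bond acceptors, and neither carries a net charge. Nothing available explains why the number rises.

The step changes the ring and adds bromine together, so the compounds shown leave open which of the two matters. Plain furan-2-yl or 5-bromopyridin-2-yl at this place would separate those two changes.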